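This account rests on a few compounds, and the source may have more. Where it says the series, first, only, none or still open, it means among the compounds named here.

Measured compounds in a functional assay on MKN-45 cells (Homo sapiens) for cytotoxicity, read by MTT assay, with a stated time of 48 h; a higher number here means a weaker inhibitor, a lower number a stronger inhibitor:
compound 1 `COc1cc(-c2nnc(SCc3ccccc3)n2N2C(=O)c3ccccc3C2=O)cc(OC)c1OC` gives > 200000 nM, a limit of the assay and not a number.
compound 2 `COc1cc(-c2nnc(SCC(=O)c3ccccc3C)n2N2C(=O)c3ccccc3C2=O)cc(OC)c1OC` gives > 200000 nM, likewise a limit of the assay rather than a number.

Compound 2 thus stands at the limit, as does compound 1; both values sit at the limit described by the limit of > 200000 nM in this assay, at which 2 of the 2 values shown sit. The step that the two limits leave unreadable from compound 1 to compound 2, (2-methylphenyl)carbonyl in place of phenyl on a saturated chain carbon bound to a sulfur, cannot be sized, since both of its ends are limits.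

Compound 3 `COc1cc(-c2nnc(SCC(=O)c3ccc(Br)cc3)n2N2C(=O)c3ccccc3C2=O)cc(OC)c1OC` differs from compound 2 by 4-bromophenyl in place of 2-methylphenyl on a carbonyl carbon; cut one bond further out this reads (2-methylphenyl)carbonyl to (4-bromophenyl)carbonyl. For the measured compounds named here, the only measured step bearing on this change is the one from compound 1 to compound 2, and it gives no size. Nothing among the shown measurements brings any member of the shared core to a readable number, so no step beyond the scatter is expected in this assay, and the most likely outcome for compound 3 is again a limit.

Compound 3 is expected at 250000 nM, within 50000 nM to 1000000 nM. The step that the limit leaves unreadable from compound 2 to compound 3 is expected to be essentially nil.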

Compound 3, half-maximal inhibitory concentration: 22300 nM
Compound 3: middle estimate off by 11-fold (1.05 log units), on the high side, outside the stated range (below it).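

In this assay, the change to a (4-bromophenyl)carbonyl group on the saturated chain carbon bound to a sulfur brings the shared core to its first readable number, with compound 3 at 22300 nM. Read on a carbonyl carbon, 4-bromophenyl in place of 2-methylphenyl gives an at least 8.9-fold lower number from compound 2 to compound 3 (0.95 log units; beyond the scatter), and (4-bromophenyl)carbonyl in place of phenyl gives an at least 8.9-fold lower number from compound 1 to compound 3 (0.95 log units; beyond the scatter); each has a limit at one end, so the true size of each step may be larger. The step between the two compounds without a number cannot be read, so a carbonyl-bearing chain alone does not account for the readable value, as compound 2 carries one and still sits at the limit, and most of the series remains unquantified: the limit of > 200000 nM in this assay, at which 2 of the 3 values shown sit.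

The compounds shown do not separate the identity of the ring substituent from its place, since bromine and methyl differ in both between 4-bromophenyl and 2-methylphenyl, and a 4-methylphenyl or 4-chlorophenyl group would bear on that question. Also open, on these data alone, is how an amine or a carboxylic acid on the same ring would read in this assay.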